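Aryl exchange on the double-bonded nitrogen

A few compounds are considered here, and "the series" means these few. Any claim that something is new, unique, unknown or untested is made for them only; others in the source may bear on it.

Compound 1 `CCOC(=O)C1=C(N/C=N/c2ncc(-c3ccccc3)s2)Nc2[nH]nc(C)c2C1c1ccc(N(C)C)cc1` gives 9790 nM in a functional assay on HepG2 cells (Homo sapiens) for inhibition, read by MTT assay, with a stated time of 48 h; on this read-out lower numbers stand for stronger inhibition and higher numbers for weaker inhibition. Compound 2 `CCOC(=O)C1=C(N/C=N/c2nnc(S(N)(=O)=O)s2)Nc2[nH]nc(C)c2C1c1ccc(N(C)C)cc1` gives 38100 nM, and compound 3 `CCOC(=O)C1=C(N/C=N/c2ccccn2)Nc2[nH]nc(C)c2C1c1ccc(N(C)C)cc1` gives 26200 nM. Compound 3 thus holds the second highest number of the three: the step of a 1.5-fold lower number from compound 2 to compound 3 (0.16 log units; within the scatter) lies within the scatter, while a 2.7-fold higher number from compound 1 to compound 3 (0.43 log units; beyond the scatter) sets it apart from compound 1. Compound 4 `CCOC(=O)C1=C(N/C=N/c2ccc([N+](=O)[O-])cc2)Nc2[nH]nc(C)c2C1c1ccc(N(C)C)cc1` differs from compound 3 by 4-nitrophenyl in place of pyridin-2-yl on a double-bonded nitrogen. Among the measured compounds shown here, no measured step involves 4-nitrophenyl; the steps of a 3.9-fold higher number from compound 1 to compound 2 (0.59 log units; beyond the scatter) and a 2.7-fold higher number from compound 1 to compound 3 (0.43 log units; beyond the scatter) show that exchanging the group on this nitrogen moves the number only modestly, and two of the three variants sit within scatter of one another. A step of about a 1.3-fold lower number from compound 3 to compound 4 (0.12 log units; within the scatter) is therefore expected, not beyond the scatter. Compound 4 is estimated at 20000 nM, with a range of 8000 nM to 50000 nM.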

Compound 4, half-maximal inhibitory concentration: 50900 nM
Compound 4: middle estimate off by 2.5-fold (0.41 log units), on the low side; the measured number lies above the stated range.
By their numbers in this assay, from the lowest: compound 1; then compounds 3, 2 and 4 (each within the scatter of the next).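

With 4-nitrophenyl on the double-bonded nitrogen, an aromatic ring of carbon only joins the set, yet the steps of a 1.9-fold higher number from compound 3 to compound 4 (0.29 log units; within the scatter) and a 1.3-fold higher number from compound 2 to compound 4 (0.13 log units; within the scatter) stay within the scatter. Among these four groups only 5-phenyl-1,3-thiazol-2-yl stands apart, and a 5.2-fold higher number from compound 1 to compound 4 (0.72 log units; beyond the scatter) is the widest step seen at this position. No evidence on the cause of this separation is available.

Going by these compounds, whether an amine or a carboxylic acid in place of the nitro group of 4-nitrophenyl would stay with compound 4 or move towards compound 1 remains open.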